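Fluoro to Bromo on the Aryl Ring: Cytotoxicity in J774 Cells

The source may hold more compounds than are shown below. What is called first, only, known or untested is meant among the compounds shown, and "the series" means these compounds.

This account concerns four hydrazone compounds built on a shared core, three of which have been measured in an ADME assay on J774 cells (Mus musculus) for cytotoxicity, read by MTT assay, with a stated time of 48 h, tested at 50 ug/mL; a lower number here means a stronger effect, a higher number a weaker effect of the compound at the concentration tested. Going by the values given here, compound 1 `O=C(N/N=C/c1ccccc1F)c1cnccn1` is the first; in this assay compound 1 gives 100%. Compound 3 `O=C(N/N=C/c1ccccc1Br)c1cnccn1` differs from compound 1 by bromo in place of fluoro on an aromatic carbon, and the measured result is a number 2 percentage points lower from compound 1 to compound 3 (within the scatter). In this assay compound 3 gives 98%. Compound 2 `O=C(N/N=C/c1ccc(F)cc1)c1cnccn1` shares its atoms with compound 1, joined differently; the difference between the two cores is not broken down here. In this assay compound 2 gives 78%, the lowest of the three numbers, standing beyond the scatter from both compound 3 and compound 1.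

Compound 4 `O=C(N/N=C/c1ccc(Br)cc1)c1cnccn1` has not yet been measured. It differs from compound 2 by bromo in place of fluoro on an aromatic carbon. This is the same kind of change as that from compound 1 to compound 3, though not the same: in compound 1 the exchanged halogen sits ortho to a large group, whereas in compound 2 it sits para to a large group.

Because the change from compound 1 to compound 3 produced a number 2 percentage points lower from compound 1 to compound 3 (within the scatter), the corresponding change is expected to leave compound 4 close to compound 2, with an estimated step of a number 1 percentage points lower from compound 2 to compound 4 (within the scatter). The expectation rests on a single measured pair, so the range is kept wide. Compound 4 is estimated at 77%, expected to fall between 62% and 92%.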

Compound 4, a percentage reported as activity, at one concentration (the size of the read-out at that concentration, not a potency): 100%
Estimate against measurement, compound 4: 23 percentage points below, outside the stated range (above it).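

In this assay, the exchange of fluoro for bromo gave a clear result on the second core, with a number 22 percentage points higher from compound 2 to compound 4 (beyond the scatter). Set beside the earlier step, the same exchange did not carry over from one core to the other: the same change on two cores in this assay, a number 2 percentage points lower (within the scatter) from compound 1 to compound 3 and a number 22 percentage points higher (beyond the scatter) from compound 2 to compound 4, 24 percentage points apart, beyond the scatter of two such steps

Going by these compounds alone, this shows that, within these two pairs, the step measured on one core could not be used to predict the step on the other, but it does not show why the two cores differ, nor does it establish a rule for the series, since it rests on only two pairs and a single pair of halogens. The compounds shown leave open how a chloro group, a methoxy group or an amine would read in this assay if it stood on the aromatic ring in place of the halogen. They also leave open whether the exchange of fluoro for bromo on a further core would resemble the small step seen on the core of compound 1 or the larger one seen on the core of compound 2.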